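A Single Methyl Added to Compound 1

The source may hold more compounds than are shown below. What is called first, only, known or untested is meant among the compounds shown, and "the series" means these compounds.

Compound 1, `COc1ccc(/C=C2\CN(C)CC3C2=NN(c2nc(-c4ccc(Cl)cc4)cs2)C3c2ccc(OC)cc2)cc1`, was tested in a functional assay on Ehrlich cells (Mus musculus) for cytotoxicity, read by trypan blue exclusion, with a stated time of 24 h, tested at 50 uM (a higher number here means a stronger effect of the compound at the concentration tested, a lower number a weaker effect), where compound 1 gives 58%. Two other compounds were measured in the same way. Compound 2, `COc1ccc(/C=C2\CCCC3C2=NN(C2=NC(=O)/C(=C/c4ccc(OC)c(OC)c4)S2)C3c2ccc(OC)cc2)cc1`, gives 40% in this assay, a value that lies beyond the scatter below compound 1. Compound 3, `COc1cc(/C=C2\CCCc3c2nc(N)c(C#N)c3-c2ccc(O)c(OC)c2)ccc1O`, gives 84% in this assay, a value beyond the scatter above compound 1. Compound 1 therefore stands second highest of the three numbers, closer to compound 2 than to compound 3.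

Compound 4, `CCN1C/C(=C\c2ccc(OC)cc2)C2=NN(c3nc(-c4ccc(Cl)cc4)cs3)C(c3ccc(OC)cc3)C2C1`, has not yet been measured. It differs from compound 1 in one place: methyl in place of hydrogen on a saturated chain carbon bound to an amine nitrogen in a ring. Cut one bond further out, the same difference reads methyl to ethyl. Going by the values given here, no pair of measured compounds here differs in a single place, so no measured step shows how such a change plays out in this assay. With only the value of compound 1 as footing, a small step in this assay is expected, in either direction, and none beyond the scatter. The estimate for compound 4 is 58%, with a range from 40% to 75%. The step that this estimate means, no change at the digits printed from compound 1 to compound 4 (within the scatter), is expected to stay within the usual scatter.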

Compound 4, a percentage reported as activity, at one concentration (the size of the read-out at that concentration, not a potency) in the Ehrlich assay: 100%
Beside the measured number, compound 4's estimate is 42 percentage points below it, outside the stated range (above it).
By their numbers in the Ehrlich assay, from the lowest: compound 2; then compound 1; then compound 3; then compound 4.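

Going by these compounds alone, this is the first step in the set that changes just one place, and it shows that this position on the amine nitrogen is not a silent one. In the Ehrlich assay, methyl in place of hydrogen on a saturated chain carbon bound to an amine nitrogen in a ring, which turns methyl into ethyl, gives a number 42 percentage points higher from compound 1 to compound 4 (beyond the scatter). The change also shows in a second read-out: in a physicochemical assay for inhibition, read by colorimetric assay, tested at 1 mg/mL (a higher number here means more inhibition at the concentration tested (going by the name of the read-out), a lower number less inhibition), compound 1 gives 69.6% and compound 4 gives 82.6%, and in the physicochemical assay that is a number 13 percentage points higher from compound 1 to compound 4 (beyond the scatter), so both numbers rise with this one added carbon.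

The compounds shown do not tell whether the numbers would keep rising with a longer chain such as propyl, or how a branched isopropyl group or a bare hydrogen on that nitrogen would compare. With a single pair, they also leave open why so small a change moves the cell read-out this far, and whether the same change would act in the same way on a different core.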